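The source may report more compounds than this note shows. Statements on the series, on what has been measured and on what is new or still open speak of the compounds shown alone.

Compound 1 `Cc1cc2c(cc1C(=O)N=C(N)N)S(=O)(=O)CC2C(C)C`: 77 nM
Compound 2 `Cc1cc2c(cc1C(=O)N=C(N)N)S(=O)(=O)C(C)(C)C2(C)O`: 102 nM
Compound 3 `Cc1cc2c(cc1C(=O)N=C(N)N)S(=O)(=O)C(C)(C)C2C`: 306 nM

These numbers come from a functional assay for inhibition, with Homo sapiens as the target; on this read-out lower numbers stand for stronger inhibition and higher numbers for weaker inhibition. Compound 1 and compound 2 lie within the usual scatter of each other, and compound 3 has a higher number than either. The unmeasured compound 4 `Cc1cc2c(cc1C(=O)N=C(N)N)S(=O)(=O)CC2N` keeps the core of compound 1 but carries amino in place of isopropyl on a saturated ring carbon. Among the measured compounds shown here, no measured step makes this exact change. The closest evidence is a 3.0-fold higher number from compound 2 to compound 3 (0.48 log units; beyond the scatter), with hydrogen in place of hydroxy on a saturated ring carbon. That modest step shows that a change at such a carbon can move the number, but it does not settle the direction here. A modest rise, with wide uncertainty, is expected: a 1.9-fold higher number from compound 1 to compound 4 (0.29 log units; within the scatter). In this assay the estimate for compound 4 is 150 nM, within a range of 40 nM to 550 nM.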

Compound 4, half-maximal inhibitory concentration: 692 nM
Compound 4: middle estimate off by 4.6-fold (0.66 log units), on the low side; the measured number lies above the stated range.
By their numbers in this assay, from the lowest: compounds 1 and 2 (each within the scatter of the next); then compound 3; then compound 4.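

In this assay, amino in place of isopropyl on this saturated ring carbon gives a 9.0-fold higher number from compound 1 to compound 4 (0.95 log units; beyond the scatter) and so places compound 4 last of the four compounds. The position is therefore not indifferent to what it carries, and this change clearly weakens inhibition. Nothing shown here offers an explanation for the rise.

As far as these compounds go, it remains open whether losing the isopropyl or gaining the amino matters more. A cyclopropyl group or an aminomethyl group at this carbon would help separate the two.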